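This account rests on a few compounds, and the source may have more. Where it says the series, first, only, none or still open, it means among the compounds named here.

Compound 2 `N#CC1CN1C(N)=O` is the smallest member of the set; in a functional assay on WiDr cells (Homo sapiens) for inhibition (on this read-out lower numbers stand for stronger inhibition and higher numbers for weaker inhibition), compound 2 returns only a limit, > 280000 nM, so its standing rests on the limit of > 280000 nM in this assay, at which 1 of the 2 values shown sits, rather than on a number. Compound 1 `CC(C)(C)NC(=O)N1CC1C#N`, which carries tert-butyl on the amide-type nitrogen, likewise returns only a limit in this assay, > 300000 nM. The step that the two limits leave unreadable from compound 1 to compound 2, hydrogen in place of tert-butyl on an amide-type nitrogen, therefore cannot be sized from the limit of > 300000 nM in this assay, at which 1 of the 2 values shown sits, and (the limit of > 280000 nM in this assay, at which 1 of the 2 values shown sits). Compound 3 `CCNC(=O)N1CC1C#N` differs from compound 2 by ethyl in place of hydrogen on an amide-type nitrogen. For the measured compounds named here, the one measured step that touches the same nitrogen is unreadable, so it gives no direction and no size to carry over. Both measured compounds sit at the edge of what this assay can report, and compound 3 is expected to stay there as well, with a step that the limit leaves unreadable from compound 2 to compound 3 not expected to exceed the scatter. Compound 3 is estimated at 300000 nM in this assay, within 150000 nM to 1000000 nM.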

Compound 3, half-maximal inhibitory concentration: 7000 nM
Beside the measured number, compound 3's estimate is 43-fold (1.63 log units) above it, and the stated range ends above it.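

On the amide-type nitrogen, the group carried there decides whether this assay gives a readable number at all: ethyl shows an at least 40-fold lower number from compound 2 to compound 3 (1.60 log units; beyond the scatter), and against the tert-butyl compound it shows an at least 42-fold lower number from compound 1 to compound 3 (1.63 log units; beyond the scatter). Ethyl therefore stands apart from both hydrogen and tert-butyl at this place, and the three compounds do not form a simple run from the smallest group to the largest. The first step is a bound and not a full size, since compound 2 returns only a limit: the limit of > 280000 nM in this assay, at which 1 of the 3 values shown sits.

Going by these compounds, the second step is likewise only a bound, since compound 1 also returns only a limit: the limit of > 300000 nM in this assay, at which 1 of the 3 values shown sits. Whether methyl, n-propyl or a longer chain on the same nitrogen would match ethyl, or return to a limit, remains open.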